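Trimming the carbamate of compound 2 to a pyridyl ether

The compounds below may be only part of what the source reports. "The series", "measured", "known", "first", "only" and "open" are said of these compounds alone.

Measured so far:
compound 1, `COc1nc(C)c(Nc2nc(Cl)cn([C@H](COC(=O)c3ccccn3)C3CC3)c2=O)cc1C`: 67 nM
compound 2, `COc1nc(C)c(Nc2nc(Cl)cn([C@H](COC(=O)Nc3cc(Cl)cc(Cl)c3)C3CC3)c2=O)cc1C`: 1.7 nM
compound 3, `COc1ccc(NC(=O)OC[C@H](C2CC2)n2cc(Cl)nc(Nc3cc(C)c(OC)nc3C)c2=O)c(C)n1`: 9.2 nM

These three compounds were tested in an assay on frontal cortex for displacement of a labelled ligand from corticotropin-releasing factor receptor 1 (Rattus norvegicus), with a stated time of 2 h; a lower number here means a stronger inhibitor, a higher number a weaker inhibitor. Compound 2 gives the lowest number of the three; compound 3 stands nearest, a 5.4-fold higher number from compound 2 to compound 3 (0.73 log units; beyond the scatter), and compound 1 stands furthest, a 39-fold lower number from compound 1 to compound 2 (1.60 log units; beyond the scatter). Compound 4, `COc1nc(C)c(Nc2nc(Cl)cn([C@H](COc3cccnc3)C3CC3)c2=O)cc1C`, has not been measured. It differs from compound 2 in one place: pyridin-3-yl in place of (3,5-dichlorophenyl)carbamoyl on an oxygen on a saturated carbon.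

For the measured compounds named here, two measured steps bear on this change. Both show that the group on that oxygen matters strongly: swapping the pyridin-2-yl of compound 1 for the (3,5-dichlorophenyl)amino of compound 2 changed the number a great deal, a 39-fold lower number from compound 1 to compound 2 (1.60 log units; beyond the scatter), and swapping that group for 6-methoxy-2-methylpyridin-3-yl changed it modestly, a 5.4-fold higher number from compound 2 to compound 3 (0.73 log units; beyond the scatter). Compound 4 removes the carbonyl and the aromatic amine altogether and keeps only a small pyridine, so a weaker result than compound 2 is expected, a 29-fold higher number from compound 2 to compound 4 (1.47 log units; beyond the scatter). Compound 4 is estimated at 50 nM, likely between 10 nM and 250 nM.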

Compound 4, half-maximal inhibitory concentration: 6.7 nM
For compound 4 the middle estimate is 7.5-fold (0.87 log units) above the measured one; measured number below the stated range.
By their numbers in this assay, from the lowest: compound 2; then compounds 4 and 3 (each within the scatter of the next); then compound 1.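

The carbamate is not essential at this position: with the carbonyl and the amide hydrogen gone and only pyridin-3-yl left on the oxygen, the cost is modest (a 3.9-fold higher number from compound 2 to compound 4 (0.60 log units; beyond the scatter)). Against the carbamate bearing 6-methoxy-2-methylpyridin-3-yl, the ether shows no real difference (a 1.4-fold lower number from compound 3 to compound 4 (0.14 log units; within the scatter)), and against the pyridin-2-yl carbonyl group it does clearly better (a 10-fold lower number from compound 1 to compound 4 (1.00 log units; beyond the scatter)), so a larger group on this oxygen does not always give a lower number, although compound 2, with the largest group, still gives the lowest. No measurement offered here explains these differences.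

As far as these compounds go, how a plain phenyl ether, a pyridin-4-yl ether or a simple methyl ether on this oxygen would compare remains open. So does whether adding chlorine to the pyridin-3-yl ring would lower the number further.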